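An ester-to-amide step on a shared core

The source may report more compounds than this note shows. Statements on the series, on what has been measured and on what is new or still open speak of the compounds shown alone.

Measured compounds:
Compound 1, `CCn1c(C(=O)NCC#N)ccc1C(CC)(CC)c1ccc(OCCC(O)(CC)CC)c(C)c1`, gives 1080 nM in an assay on cells for agonist activity at vitamin D3 receptor (Homo sapiens), with a stated time of 96 h; a lower number here means that less compound is needed, a higher number that more compound is needed for the effect.
Compound 2, `C#CCCOC(=O)c1ccc(C(CC)(CC)c2ccc(OCCC(O)(CC)CC)c(C)c2)n1CC`, gives 6030 nM in this assay.

Among the measured compounds shown here, compound 2 holds the highest of the two numbers; its only neighbour is compound 1, which sits a 5.6-fold higher number from compound 1 to compound 2 (0.75 log units; beyond the scatter) apart in the other direction. For the measured compounds named here, that single step, an ester taking the place of an amide on the carbonyl carbon, is the one measured change that bears on the next compound.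

Compound 3, `CCC(C)C(NC(=O)c1ccc(C(CC)(CC)c2ccc(OCCC(O)(CC)CC)c(C)c2)n1CC)C(=O)OC`, returns to an amide on that carbonyl carbon: a group of 10 heavy atoms (7 carbon, 1 nitrogen, 2 oxygen; no ring) in place of a group of 5 heavy atoms (4 carbon, 1 oxygen; no ring), on a carbonyl carbon. Since the reverse exchange gave a 5.6-fold higher number from compound 1 to compound 2 (0.75 log units; beyond the scatter), compound 3 is expected to move back toward the lower number of compound 1, though the entering group is larger, so the expected step is a 3.4-fold lower number from compound 2 to compound 3 (0.53 log units; beyond the scatter). Compound 3 is therefore estimated at 1800 nM, within 500 nM to 7000 nM.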

Compound 3, half-maximal effective concentration: > 10000 nM
Compound 3: only a limit was reported; the forecaster's own chance of this, stated with the estimate: 5%; middle value at least 5.5-fold (0.74 log units) from the limit.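

The value of compound 3 is a limit of the assay, not a number: the limit of > 10000 nM in this assay, at which 1 of the 3 values shown sits. Against the ester, the step reads an at least 1.6-fold higher number from compound 2 to compound 3 (0.21 log units; that floor lies within the scatter), so the limit alone does not set the new amide clearly apart from the (but-3-yn-1-yl)oxy group. Against the other amide, the step reads an at least 9.2-fold higher number from compound 1 to compound 3 (0.96 log units; beyond the scatter), which shows that an amide on this carbonyl carbon does not by itself bring the lower number; what sits on the amide-type nitrogen matters as well.

The compounds shown leave open how far past the limit compound 3 lies, and which part of the entering group goes with the higher number, its branched carbon chain or its methyl ester. A carboxylic acid in place of that ester, or a simple unbranched amide chain, would bear on this.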